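The compounds below may be only part of what the source reports. "The series", "measured", "known", "first", "only" and "open" are said of these compounds alone.

Two compounds have been measured in a functional assay on LoVo cells (Homo sapiens) for cytotoxicity, read by colorimetric assay and MTT assay; a lower number here means a stronger inhibitor, a higher number a weaker inhibitor:
compound 1, `COc1cc(OC)c2cc(-c3ccc(OCc4ccccc4)cc3)c(O)nc2c1`, which gives 10000 nM;
compound 2, `COc1ccc(-c2cc3c(OC)cc(OC)cc3n(C)c2=O)cc1`, which gives 10000 nM.

On these numbers compound 2 stands level with compound 1 at the digits shown; the gap between them lies within the scatter of repeated measurements. The two share a core yet differ in more than one place, so no single step can be read off between them.

Compound 3, `COc1ccc(-c2cc3c(OC)cc(OC)cc3n(CC(=O)OCc3ccccc3)c2=O)cc1`, has not yet been measured in this assay. It differs from compound 2 in one place: benzyloxycarbonyl in place of hydrogen on a saturated chain carbon bound to an aromatic nitrogen. Read one bond further out, the change is methyl to (benzyloxycarbonyl)methyl.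

Among the measured compounds shown here, with no measured step to anchor the size of this change, and with both measured compounds at the same weak value, compound 3 is expected to stay near compound 2, the step of no change at the digits printed from compound 2 to compound 3 (within the scatter) being no larger than the scatter in either direction. The estimate for compound 3 is 10000 nM, within 3000 nM to 30000 nM.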

Compound 3, half-maximal inhibitory concentration: 10000 nM
For compound 3 middle estimate and measured number coincide at the digits printed; measured number inside the range.
By their numbers in this assay, from the lowest: compounds 1, 2 and 3 (each within the scatter of the next).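

In this assay, among the compounds shown here, the change of methyl to (benzyloxycarbonyl)methyl on the aromatic nitrogen gives the first step that can be read, no change at the digits printed from compound 2 to compound 3 (within the scatter). It shows that benzyloxycarbonyl in place of hydrogen on this saturated chain carbon, which brings in 10 heavy atoms and a six-membered aromatic ring of carbon only, leaves the number where it stood, something the earlier pair could not show because those two compounds differ in more than one place. Nothing measured here bears on why the number stays put.

Going by these compounds, whether a carboxylic acid, an amine or a longer chain in this place would give a lower number remains open. So does whether any single change on the shared core moves the number at all.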